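A Hydroxycyclohexylmethyl Analogue of a Kinase Inhibitor Series

The source may report more compounds than this note shows. Statements on the series, on what has been measured and on what is new or still open speak of the compounds shown alone.

Of the compounds shown here, two sharing one core have been measured in an assay on isolated protein for inhibition of protein kinase C theta type (Homo sapiens), read by TR-FRET, with a stated time of 2 h; a higher number here means a weaker inhibitor, a lower number a stronger inhibitor. Compound 1 `N#Cc1cnc(NCc2cnccc2C(F)(F)F)cc1NC[C@H]1C[C@H](O)C1` gives 700 nM in this assay, and compound 2 `CO[C@H]1CC[C@H](Nc2cc(NCc3cnccc3C(F)(F)F)ncc2C#N)CC1` gives 1100 nM. Compound 2 has the higher of the two numbers, but the step of a 1.6-fold higher number from compound 1 to compound 2 (0.20 log units; within the scatter) lies within the scatter, so the two are indistinguishable on this evidence. Compound 3 `N#Cc1cnc(NCc2cnccc2C(F)(F)F)cc1NC[C@H]1CC[C@@H](O)CC1` has not yet been measured in this assay. The change it makes is (4-hydroxycyclohexyl)methyl in place of 4-methoxycyclohexyl on a nitrogen on an aromatic ring. Among the compounds with values here, only one measured step bears on it: the step from compound 1 to compound 2 exchanged a hydroxylated ring-methyl group for a methoxylated ring and gave no change beyond the scatter, and compound 3 returns to a hydroxylated ring-methyl group. No step beyond the scatter is therefore expected, with a 1.4-fold lower number from compound 2 to compound 3 (0.14 log units; within the scatter) as the estimated step. Compound 3 is expected to give about 800 nM in this assay, within a range from 300 nM to 2500 nM.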

Compound 3, half-maximal inhibitory concentration: 58 nM
For compound 3 the middle estimate is 14-fold (1.14 log units) above the measured one; the measured number lies below the stated range.
By their numbers in this assay, from the lowest: compound 3; then compounds 1 and 2 (each within the scatter of the next).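

Read in this assay, the group on this nitrogen on an aromatic ring clearly affects the number, although the earlier pair had stayed within the scatter: moving from 4-methoxycyclohexyl to (4-hydroxycyclohexyl)methyl gives a 19-fold lower number from compound 2 to compound 3 (1.28 log units; beyond the scatter), even though the two groups have the same heavy-atom count. Ring size on the saturated chain carbon also matters, as 4-hydroxycyclohexyl in place of 3-hydroxycyclobutyl gives a 12-fold lower number from compound 1 to compound 3 (1.08 log units; beyond the scatter), with the chain and hydroxyl retained. No measurement at hand bears on the reason for either step.

The first step changes both the chain carbon and the methoxy-to-hydroxyl group at once, so a (4-methoxycyclohexyl)methyl group would be needed to separate their contributions. From the compounds shown here alone, whether an amine or a carboxylic acid at the ring position held by the hydroxyl would fare similarly also remains open.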